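From 4-chlorophenyl to anilino on the carbonyl carbon

The source may report more compounds than this note shows. Statements on the series, on what has been measured and on what is new or still open speak of the compounds shown alone.

Three compounds have so far been tested in an assay on isolated protein for inhibition of Substance-P receptor (Cavia porcellus), tested at 1 ug/mL; a higher number here means more inhibition at the concentration tested (going by the name of the read-out), a lower number less inhibition:

Compound 1 `COc1cc(C(=O)N2CO[C@](CCN3CCC4(CC3)CN(Cc3ccccc3)C(=O)O4)(c3ccc(Cl)c(Cl)c3)C2)cc(OC)c1OC` gives 86%.
Compound 2 `COc1cc(C(=O)N2CO[C@](CCN3CCC(C(=O)c4ccc(Cl)cc4)CC3)(c3ccc(Cl)c(Cl)c3)C2)cc(OC)c1OC` gives 97%.
Compound 3 `COc1cc(C(=O)N2CO[C@](CCN3CCN(c4ccccn4)CC3)(c3ccc(Cl)c(Cl)c3)C2)cc(OC)c1OC` gives 100%.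

Compound 2 stands second highest of these three numbers. Its gap to compound 3 lies within the usual scatter, so the two cannot be told apart; compound 1 sits lower by a gap beyond the scatter. Within the data shown here, no step between measured compounds that differ in a single place is available, so no single structural change has yet been tied to a measured shift.

Compound 4 `COc1cc(C(=O)N2CO[C@](CCN3CCC(C(=O)Nc4ccccc4)CC3)(c3ccc(Cl)c(Cl)c3)C2)cc(OC)c1OC` is the next compound, not yet measured. Set against compound 2, it differs in one place: anilino in place of 4-chlorophenyl on a carbonyl carbon. Seen one bond further out, a (4-chlorophenyl)carbonyl becomes a phenylcarbamoyl. Since compound 1, compound 2 and compound 3 all give high inhibition despite quite different groups in this part of the molecule, the step from compound 2 to compound 4 is expected to be small, either none beyond the scatter or a modest fall, a number 7 percentage points lower from compound 2 to compound 4 (within the scatter). Compound 4 is therefore estimated at 90%, within a range from 74% to 100%.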

Compound 4, a percentage reported as inhibition, at one concentration (the size of the read-out at that concentration, not a potency): 44%
Compound 4: the middle estimate sits 46 percentage points above what was measured; measured number outside the range, below it.
By their numbers in this assay, from the lowest: compound 4; then compound 1; then compounds 2 and 3 (each within the scatter of the next).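

In this assay, among these compounds, replacing 4-chlorophenyl with anilino on the carbonyl carbon gives a number 53 percentage points lower from compound 2 to compound 4 (beyond the scatter) and is the first single change tied to a measured shift. It shows that what sits on this carbonyl carbon can matter greatly, even though the two groups have the same count of heavy atoms and each holds one six-membered aromatic ring of carbon only. The change does two things at once, removing the chlorine and adding a hydrogen-bond donor, the amide hydrogen, and no measurement shown here explains the fall.

The compounds shown leave open which of those two differences matters. A 4-chloroanilino group on the same carbonyl carbon would restore the chlorine while keeping the amide hydrogen, and a methyl group on the amide nitrogen would remove that hydrogen while leaving the chlorine absent.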